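The compounds below may be only part of what the source reports. "The series", "measured", "known", "first", "only" and "open" are said of these compounds alone.

Compound 1 `CC(C)(c1ccccc1)c1nc2c(C(F)(F)F)cccc2c(C(=O)O)c1O` gives 59% in an assay on isolated protein for inhibition of P-selectin glycoprotein ligand 1 (Homo sapiens), read by surface plasmon resonance, tested at 250 uM (a higher number here means more inhibition at the concentration tested (going by the name of the read-out), a lower number less inhibition), while compound 2 `O=C(O)c1c(O)c(C2(c3cccs3)CC2)nc2c(C(F)(F)F)cccc12` gives 15% in the same assay. For the measured compounds named here, compound 2 therefore stands lowest of the two measured compounds, with compound 1 its only neighbour at a clearly higher number. Going by the values given here, the single measured step, a number 44 percentage points lower from compound 1 to compound 2 (beyond the scatter), shows that exchanging the 1-methyl-1-phenylethyl group for the 1-(thiophen-2-yl)cyclopropyl group on the shared core was a large loss.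

Compound 3 `O=C(O)c1c(O)c(C2Cc3ccccc3C2)nc2c(C(F)(F)F)cccc12` is not yet measured. It differs from compound 2 by 2,3-dihydro-1H-inden-2-yl in place of 1-(thiophen-2-yl)cyclopropyl on an aromatic carbon. Among the compounds with values here, the only step that bears on this position is the one from compound 1 to compound 2, and it was large, so the position clearly matters; but no measured pair shows what a 2,3-dihydro-1H-inden-2-yl group does there, and the new group resembles neither of the two measured groups closely. Compound 3 is therefore expected to show a rise of a number 15 percentage points higher from compound 2 to compound 3 (beyond the scatter) from compound 2, moving part of the way back toward compound 1, though with wide uncertainty. For compound 3 the estimate is 30%, within a range of 8% to 55%.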

Compound 3, a percentage reported as inhibition, at one concentration (the size of the read-out at that concentration, not a potency): 35%
Beside the measured number, compound 3's estimate is 5 percentage points below it; low and high end bracket the measured number.
By their numbers in this assay, from the lowest: compound 2; then compound 3; then compound 1.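

In this assay, the 2,3-dihydro-1H-inden-2-yl group wins back part of what the thiophene-bearing group lost, with a number 20 percentage points higher from compound 2 to compound 3 (beyond the scatter), yet it does not restore the level of the 1-methyl-1-phenylethyl group, with a number 24 percentage points lower from compound 1 to compound 3 (beyond the scatter). The position therefore now separates three groups at three distinct levels, and the two groups with a six-membered aromatic ring of carbon only both stand above the group with the five-membered aromatic ring, although the gap between those two shows that this ring alone does not fix the number. Nothing measured here accounts for these differences.

Each step exchanges a whole group, so the compounds shown do not tell whether the thiophene ring, the cyclopropyl ring or their combination goes with the low number of compound 2. Also open, as far as these compounds go, is how a 1-phenylcyclopropyl group or a 2-(thiophen-2-yl)propan-2-yl group, each of which would pull those two features apart, would read at this position, and what a group carrying an amine would do there.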